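Swapping the piperidine substituent: from difluoro to hydroxyl

A few compounds are considered here, and "the series" means these few. Any claim that something is new, unique, unknown or untested is made for them only; others in the source may bear on it.

Measured compounds, with their values in an ADME assay on microsomes from liver (Rattus norvegicus) for pharmacokinetics; a higher number here means faster removal of the compound, a lower number slower removal:
compound 1 `Fc1ccccc1Cn1nc(-c2ncc(F)c(N3CCCC3)n2)cc1-c1ccon1` gives 500 uL/min;
compound 2 `Fc1ccccc1Cn1nc(-c2ncc(F)c(N3CCCCC3)n2)cc1-c1ccon1` gives 490 uL/min;
compound 3 `Fc1ccccc1Cn1nc(-c2ncc(F)c(N3CCC(F)(F)CC3)n2)cc1-c1ccon1` gives 340 uL/min.

Compound 3 holds the smallest of the three numbers, yet its steps to both others lie within the scatter: a 1.5-fold lower number from compound 1 to compound 3 (0.17 log units; within the scatter) and a 1.4-fold lower number from compound 2 to compound 3 (0.16 log units; within the scatter). The step of a 1.0-fold lower number from compound 1 to compound 2 (0.01 log units; within the scatter) is likewise within the scatter. Compound 4 `OC1CCCN(c2nc(-c3cc(-c4ccon4)n(Cc4ccccc4F)n3)ncc2F)C1` differs from compound 3 in one place: 3-hydroxypiperidin-1-yl in place of 4,4-difluoropiperidin-1-yl on an aromatic carbon. Going by the values given here, no measured step here involves a hydroxyl group, so the closest guides are the changes among the three piperidine and pyrrolidine variants, none of which moved beyond the scatter. The expected step is therefore a 1.1-fold higher number from compound 3 to compound 4 (0.05 log units; within the scatter), no shift beyond the scatter. Compound 4 is estimated at 380 uL/min in this assay, within a range from 190 uL/min to 760 uL/min.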

Compound 4, intrinsic clearance in a liver preparation (reported as CLH), per the amount of preparation that the assay uses: 360 uL/min
Estimate against measurement, compound 4: 1.1-fold (0.02 log units) above; the range from low to high includes it.
By their numbers in this assay, from the lowest: compounds 3, 4, 2 and 1 (each within the scatter of the next).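

The 3-hydroxypiperidin-1-yl group brings a hydrogen-bond donor to this aromatic carbon, which none of the earlier groups carried, yet in this assay every new step stays within the scatter (a 1.1-fold higher number from compound 3 to compound 4 (0.02 log units; within the scatter); a 1.4-fold lower number from compound 2 to compound 4 (0.13 log units; within the scatter); a 1.4-fold lower number from compound 1 to compound 4 (0.14 log units; within the scatter)). Adding a hydroxy group to the piperidine ring or exchanging the 4,4-difluoropiperidin-1-yl group for the hydroxylated ring therefore does not separate these compounds in this read-out.

As far as these compounds go, whether an amine or a carboxylic acid on the piperidine ring would give a step beyond the scatter remains open. Nothing available explains why these four numbers stay so close.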